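From an Ethylamide to an Ethylpiperazine Amide

The compounds below may be only part of what the source reports. "The series", "measured", "known", "first", "only" and "open" are said of these compounds alone.

Measured so far:
compound 1 `CCNC(=O)/C=C/C=C/[C@H](O)Cc1ccc(OC)c(OC)c1`: 14600 nM
compound 2 `COc1ccc(C[C@@H](O)/C=C/C=C/C(=O)N2CCN(c3ccccc3)CC2)cc1OC`: 9750 nM

In a functional assay on HeLa cells (Homo sapiens) for antiproliferative activity, read by sulforhodamine B assay, with a stated time of 48 h (a higher number here means a weaker inhibitor, a lower number a stronger inhibitor), compound 1 gives 14600 nM, the higher of the two numbers, yet compound 2 with 9750 nM lies within the usual scatter of it, so the two read as alike. Compound 3 `CCN1CCN(C(=O)/C=C/C=C/[C@H](O)Cc2ccc(OC)c(OC)c2)CC1` differs from compound 1 by 4-ethylpiperazin-1-yl in place of ethylamino on a carbonyl carbon. Going by the values given here, no step between measured compounds shows what such a change does. Because compound 2 gives 9750 nM so close to compound 1 with its own ring amide, only a small shift is expected. Compound 3 is expected to give 10000 nM, somewhere from 4000 nM to 25000 nM. The expected step of a 1.5-fold lower number from compound 1 to compound 3 (0.16 log units; within the scatter) stays within the scatter.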

Compound 3, half-maximal inhibitory concentration: 11700 nM
Compound 3: middle estimate off by 1.2-fold (0.07 log units), on the low side; low and high end bracket the measured number.
By their numbers in this assay, from the lowest: compounds 2, 3 and 1 (each within the scatter of the next).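

Putting 4-ethylpiperazin-1-yl in place of ethylamino on the carbonyl carbon gives a 1.2-fold lower number from compound 1 to compound 3 (0.10 log units; within the scatter) in this assay and so, at this position, the larger ring-bearing group and the small chain read as alike. Within the ring amides, ethyl in place of phenyl on the ring nitrogen gives a 1.2-fold higher number from compound 2 to compound 3 (0.08 log units; within the scatter) and this change also cannot be told from the scatter. Nothing measured here accounts for these results and no cause can be given.

Open, going by these compounds, is whether a free carboxylic acid or a longer chain at this carbonyl carbon would also read as alike. Also open, on these data alone, is whether a primary amide there would do so.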